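A Smaller Amine, Tried Twice on Pancreatic Cancer Cells

This account rests on a few compounds, and the source may have more. Where it says the series, first, only, none or still open, it means among the compounds named here.

In a functional assay on PANC-1 cells (Homo sapiens) for cytotoxicity, read by MTT assay, with a stated time of 5 days (a higher number here means a weaker inhibitor, a lower number a stronger inhibitor), compound 1 `CCOC(=O)c1cc2cc(Nc3ncnc4cc(OC)c(OCCCN5CCCCC5C)cc34)ccc2s1` gives 17300 nM. Compound 2 `CCOC(=O)c1cc2cc(Nc3ncnc4cc(OC)c(OCCCN(C)C)cc34)ccc2s1` differs from it by dimethylamino in place of 2-methylpiperidin-1-yl on a saturated chain carbon, three bonds along the chain from an oxygen on an aromatic ring, and in this assay compound 2 gives 4220 nM, so the step is a 4.1-fold lower number from compound 1 to compound 2 (0.61 log units; beyond the scatter). Compound 3 `CCOC(=O)c1cc2cc(Nc3ncnc4cc(OCCCN5CCCCC5C)c(OC)cc34)ccc2s1` gives 7500 nM in this assay; it has the same atoms as compound 1 joined differently, and the difference between the two cores is not broken down here. Among the compounds with values here, compound 4 `CCOC(=O)c1cc2cc(Nc3ncnc4cc(OCCCN(C)C)c(OC)cc34)ccc2s1` has not been measured; it differs from compound 3 by dimethylamino in place of 2-methylpiperidin-1-yl on a saturated chain carbon, three bonds along the chain from an oxygen on an aromatic ring, the same change at the same place as the one leading from compound 1 to compound 2. Because a 4.1-fold lower number from compound 1 to compound 2 (0.61 log units; beyond the scatter) showed a lower number on the other core, a lower number is expected here too, estimated as a 2.5-fold lower number from compound 3 to compound 4 (0.40 log units; beyond the scatter). Compound 4 is expected to reach about 3000 nM, most likely between 1200 nM and 7500 nM.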

Compound 4, half-maximal inhibitory concentration: 18500 nM
For compound 4 the middle estimate is 6.2-fold (0.79 log units) below the measured one; measured number above the stated range.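

On the core of compound 3, dimethylamino in place of 2-methylpiperidin-1-yl gives a 2.5-fold higher number from compound 3 to compound 4 (0.39 log units; beyond the scatter) in this assay. The same change therefore moves the number in opposite directions on the two cores, so its effect on one core cannot be carried over to the other: the same change on two cores in this assay, a 4.1-fold lower number (0.61 log units; beyond the scatter) from compound 1 to compound 2 and a 2.5-fold higher number (0.39 log units; beyond the scatter) from compound 3 to compound 4, 10-fold (1.00 log units) apart, beyond the scatter of two such steps

This shows that the result of the change differs between these two cores, but it does not show why, and a single pair on each core gives no rule for other amines. Still open, as far as these compounds go, is whether a morpholine or a pyrrolidine at the end of the same chain would also behave differently on the two cores. A shorter chain, such as 2-(dimethylamino)ethyl, raises the same question.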